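A ring swap on a carbonyl carbon

The compounds below may be only part of what the source reports. "The series", "measured", "known", "first", "only" and "open" are said of these compounds alone.

- compound 1 `C[C@H](NC(=O)C1CCOCC1)c1ccc(NC(=O)[C@H]2C[C@@H]2c2cccnc2)cc1`: 7 nM
- compound 2 `C[C@H](NC(=O)c1ccccc1)c1ccc(NC(=O)[C@H]2C[C@@H]2c2cccnc2)cc1`: 8 nM

In a functional assay on COR-L23 cells (Homo sapiens) for antiproliferative activity, read by CellTiter-Glo, with a stated time of 4 days (on this read-out lower numbers stand for stronger inhibition and higher numbers for weaker inhibition), compound 2 gives 8 nM, level with compound 1 at 7 nM, the two lying within the scatter of each other. Compound 3 `C[C@H](NC(=O)c1ccccn1)c1ccc(NC(=O)[C@H]2C[C@@H]2c2cccnc2)cc1` alters one group of compound 2: pyridin-2-yl in place of phenyl on a carbonyl carbon. Going by the values given here, the only measured step on that carbonyl carbon, a 1.1-fold higher number from compound 1 to compound 2 (0.06 log units; within the scatter), is within the scatter, so no step beyond the scatter is expected in this assay. Among the compounds with values here, no measured compound yet carries pyridin-2-yl, so this guide is indirect. The expected step is no change at the digits printed from compound 2 to compound 3 (within the scatter). For compound 3 the estimated value is 8 nM, with an expected range of 3 nM to 22 nM.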

Compound 3, half-maximal inhibitory concentration: 46 nM
Compound 3: the middle estimate sits 5.8-fold (0.76 log units) below what was measured; the whole stated range lies below it.
By their numbers in this assay, from the lowest: compounds 1 and 2 (each within the scatter of the next); then compound 3.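

In this assay this carbonyl carbon turns out to be sensitive to the ring it carries: pyridin-2-yl for phenyl gives a 5.8-fold higher number from compound 2 to compound 3 (0.76 log units; beyond the scatter) and pyridin-2-yl for oxan-4-yl gives a 6.6-fold higher number from compound 1 to compound 3 (0.82 log units; beyond the scatter), although phenyl and oxan-4-yl had stood level. Changing one ring carbon to nitrogen is therefore enough to weaken inhibition here. Nothing available explains this loss.

Still open, as far as these compounds go, is whether pyridin-3-yl or pyridin-4-yl would behave like pyridin-2-yl. Also open, from the compounds shown here alone, is whether an amine such as piperidin-4-yl on that carbonyl carbon would stay level with phenyl.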